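The compounds below may be only part of what the source reports. "The series", "measured", "known", "first", "only" and "open" are said of these compounds alone.

Among the compounds with values here, in a functional assay on MCF7 cells (Homo sapiens) for antiproliferative activity, read by CellTiter-Glo, with a stated time of 5 days (on this read-out lower numbers stand for stronger inhibition and higher numbers for weaker inhibition), two compounds have numbers so far. Compound 1 (`O=C(O)/C=C/c1ccc(/C(=C(\c2ccc(F)cc2Cl)C2CCC2)c2ccc3nccn3c2)cc1`) gives 4.4 nM and compound 2 (`O=C(O)/C=C/c1ccc(/C(=C(\c2ccccc2)C2CCC2)c2ccc(-c3cncs3)cc2)cc1`) gives 9.2 nM as the higher of the two numbers, a gap just beyond the usual scatter. Compound 3 (`O=C(O)/C=C/c1ccc(/C(=C(\c2ccc(F)cc2Cl)C2CCC2)c2ccc(-c3cncs3)cc2)cc1`) has not yet been measured. It differs from compound 2 in one place (2-chloro-4-fluorophenyl in place of phenyl on a double-bonded chain carbon bound to a double-bonded chain carbon and a saturated ring carbon): 2-chloro-4-fluorophenyl in place of phenyl on a double-bonded chain carbon bound to a double-bonded chain carbon and a saturated ring carbon. Within the data shown here, no measured pair isolates this change. Compound 1 also carries 2-chloro-4-fluorophenyl and gives 4.4 nM with a further difference in its core, so only a modest move is expected, perhaps none beyond the scatter. The estimated step in this assay is a 1.8-fold lower number from compound 2 to compound 3 (0.26 log units; within the scatter) toward a lower number. Compound 3 is estimated at 5 nM with 2 nM to 14 nM as the expected range.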

Compound 3, half-maximal inhibitory concentration: 4.2 nM
Compound 3: the middle estimate sits 1.2-fold (0.08 log units) above what was measured; measured number inside the range.
By their numbers in this assay, from the lowest: compounds 3 and 1 (each within the scatter of the next); then compound 2.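

In this assay, within the data shown here, 2-chloro-4-fluorophenyl in place of phenyl on a double-bonded chain carbon bound to a double-bonded chain carbon and a saturated ring carbon gives a 2.2-fold lower number from compound 2 to compound 3 (0.34 log units; beyond the scatter), which is the first direct reading of this change and a modest step beyond the scatter. The comparison at the other place, on a double-bonded chain carbon bound to an aromatic carbon and a double-bonded chain carbon, gives a 1.0-fold lower number from compound 1 to compound 3 (0.02 log units; within the scatter), within the scatter, so with 2-chloro-4-fluorophenyl present, this assay does not separate the two groups found there. Nothing available here bears on the cause of either step.

The compounds shown leave open how a 2-chlorophenyl or a 4-fluorophenyl group alone would compare with phenyl at this position. They also leave open how an amine or a methoxy group on that ring would read.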